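This account rests on a few compounds, and the source may have more. Where it says the series, first, only, none or still open, it means among the compounds named here.

Measured so far:
compound 1 `CCc1ccccc1NC(=O)N[C@@H](C)c1ccccc1` — 100%
compound 2 `CCc1cccc(CC)c1NC(=O)N[C@H](C)c1ccccc1` — 101%

In an ADME assay on the whole organism with Oryza sativa as the target, tested at 0.1 uM (on this read-out higher numbers stand for a weaker effect at the one concentration tested and lower numbers for a stronger effect), compound 1 gives 100%. Compound 2 gives 101%, the highest of the two numbers, though its gap to compound 1 lies within the scatter, so the two are not to be ranked. Compound 3 `CCc1cccc(CC)c1NC(=O)N[C@@H](C)c1ccccc1` has not yet been measured in this assay; (the two compounds have the same atoms and bonds and differ only in configuration as drawn: 1 of 1 stereo elements differ; a stereocentre at a saturated chain carbon is drawn R in compound 2 and S in compound 3). Going by the values given here, no step between measured compounds is available, so the expectation rests only on the two values, which both sit at the top of the scale. Compound 3 is therefore expected to give 100%, with a range from 90% to 108%. The estimated step of a number 1 percentage points lower from compound 2 to compound 3 (within the scatter) is expected to stay within the scatter.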

Compound 3, a percentage reported as activity, at one concentration (the size of the read-out at that concentration, not a potency): 101%
Estimate against measurement, compound 3: 1 percentage points below; the range from low to high includes it.
By their numbers in this assay, from the lowest: compounds 1, 2 and 3 (each within the scatter of the next).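

In this assay, the pair of compounds 2 and 3 tests the configuration of the stereocentre at the saturated chain carbon on its own, and the result is no change at the digits printed from compound 2 to compound 3 (within the scatter). The pair isolates that one feature: the fact that compounds 2 and 3 differ only in the configuration as drawn. Ethyl in place of hydrogen on an aromatic carbon gives a number 1 percentage points higher from compound 1 to compound 3 (within the scatter), so neither change separates the compounds on this read-out.

The compounds shown leave open whether any change to the shared core can move this read-out. An amine or a carboxylic acid in place of the ethyl remains an open case.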